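Swapping the acyl for an arylsulfonyl on compound 3

A few compounds are considered here, and "the series" means these few. Any claim that something is new, unique, unknown or untested is made for them only; others in the source may bear on it.

Compound 3 `CN(C)c1ccc(C2CC(c3ccc(-n4cncn4)cc3)=NN2C(=O)CCCl)cc1` gives -0.7% in a functional assay on NCI-H1975 cells (Homo sapiens) for inhibition, read by sulforhodamine B assay, tested at 10 uM (a higher number here means more inhibition at the concentration tested (going by the name of the read-out), a lower number less inhibition), the lowest of the three numbers. Among the compounds with values here, compound 1 `CN1CCN(c2ccc(C3=NN(C(=O)CCCl)C(c4ccc(N(C)C)cc4)C3)cc2)CC1` gives -0.2%, and the one measured step, a number 0.5 percentage points lower from compound 1 to compound 3 (within the scatter), is within the scatter. Compound 2 `CN1CCN(c2ccc(C3=NN(S(=O)(=O)c4ccc(C(F)(F)F)cc4)C(c4ccc(N(C)C)cc4)C3)cc2)CC1` gives 18.9%, which stands beyond the scatter above compound 3; compound 2 carries an arylsulfonyl on the ring nitrogen where compound 1 carries the (2-chloroethyl)carbonyl, and those two values are the only hint about such a swap. Within the data shown here, compound 4 `CN(C)c1ccc(C2CC(c3ccc(-n4cncn4)cc3)=NN2S(=O)(=O)c2ccc(F)cc2)cc1` differs from compound 3 as follows: (4-fluorophenyl)sulfonyl in place of (2-chloroethyl)carbonyl on an amine nitrogen in a ring No measured step covers this change directly, so only a rough expectation is possible. Compound 4 is estimated at 14%, between 0% and 30%, an expected rise of a number 14.7 percentage points higher from compound 3 to compound 4 (beyond the scatter).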

Compound 4, a percentage reported as inhibition, at one concentration (the size of the read-out at that concentration, not a potency): -0.5%
Estimate against measurement, compound 4: 14.5 percentage points above, outside the stated range (below it).
By their numbers in this assay, from the lowest: compounds 3, 4 and 1 (each within the scatter of the next); then compound 2.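

In this assay, (4-fluorophenyl)sulfonyl in place of (2-chloroethyl)carbonyl on this ring nitrogen gives a number 0.2 percentage points higher from compound 3 to compound 4 (within the scatter), so with 1H-1,2,4-triazol-1-yl in the molecule, this arylsulfonyl brings no detectable inhibition. The value of compound 2, 18.9%, therefore cannot be credited to a sulfonyl at this position in general. Nothing measured here explains the flat result.

Still open, as far as these compounds go, is whether the aryl group's substituent or the 4-methylpiperazin-1-yl group matters for the value of compound 2. From the compounds shown here alone, the effect of a longer acyl chain on this nitrogen is also open.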